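A few compounds are considered here, and "the series" means these few. Any claim that something is new, unique, unknown or untested is made for them only; others in the source may bear on it.

Measured compounds:
compound 1, `CCCCCCCCNC(=O)[C@@H](NC(=O)c1cccs1)[C@@H](C)O`: 149000 nM
compound 2, `CCCCCCCCNC(=O)[C@@H](NC(=O)/C=C/c1ccccc1)[C@@H](C)O`: 55600 nM
compound 3, `CCCCCCCCCCCCNC(=O)[C@@H](NC(=O)c1cccs1)[C@@H](C)O`: 30100 nM

All three were tested in a functional assay on HepG2 cells (Homo sapiens) for cytotoxicity, read by MTT assay, with a stated time of 48 h; on this read-out lower numbers stand for stronger inhibition and higher numbers for weaker inhibition. Compound 3 has the lowest of the three numbers; compound 2 sits within the scatter of it, and only compound 1 stands clearly apart, as the step of a 5.0-fold lower number from compound 1 to compound 3 (0.69 log units; beyond the scatter) shows. Compound 4, `C/C=C/C=C/C(=O)N[C@H](C(=O)NCCCCCCCCCCCC)[C@@H](C)O`, has not yet been measured in this assay. It differs from compound 3 in one place: penta-1,3-dien-1-yl in place of thiophen-2-yl on a carbonyl carbon. Among the compounds with values here, one measured step bears on this change, the exchange of the same thiophen-2-yl on the same carbonyl carbon for 2-phenylethenyl, a 2.7-fold lower number from compound 1 to compound 2 (0.43 log units; beyond the scatter), a modest move to a lower number. The group entering compound 4 is again an open chain with double bonds in place of the five-membered aromatic ring, though without the added benzene ring of that earlier case, so the same direction is expected, with a size that may fall short of the earlier step. Compound 4 is therefore expected to give a somewhat lower number, a step of a 1.8-fold lower number from compound 3 to compound 4 (0.25 log units; within the scatter). The estimate for compound 4 is 17000 nM, with a likely range from 6000 nM to 50000 nM.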

Compound 4, half-maximal inhibitory concentration: > 400000 nM
Compound 4 was reported as a limit; the forecaster's own chance of this, stated with the estimate: 5%; at least 23-fold (1.37 log units) between middle value and limit.
By their numbers in this assay, from the lowest: compounds 3 and 2 (each within the scatter of the next); then compound 1. At a limit, above all of these: compound 4.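

Compound 4 gives > 400000 nM in this assay and this reading is a limit, not a number. Even so, the exchange of thiophen-2-yl for penta-1,3-dien-1-yl on this carbonyl carbon gives an at least 13-fold higher number from compound 3 to compound 4 (1.12 log units; beyond the scatter) and is the largest step seen so far, so this place tolerates far less change than the modest earlier steps suggested. The earlier exchange here, to 2-phenylethenyl on the shorter chain of compound 1, ran the other way with a 2.7-fold lower number from compound 1 to compound 2 (0.43 log units; beyond the scatter) and shows that open groups with double bonds at this place do not share one direction.

On these data alone, the two exchanges were read on different chains, so it stays open whether the entering group alone sets the direction or whether the chain also plays a part, which 2-phenylethenyl on the longer chain of compound 3 and penta-1,3-dien-1-yl on the shorter chain of compound 1 would help to settle. As far as these compounds go, it also stays open how a saturated pentyl group or a plain phenyl ring would read on this carbonyl carbon, and how far the number for compound 4 lies past its limit.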